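Replacing Nitro with a Selenium-Bearing Group

A few compounds are considered here, and "the series" means these few. Any claim that something is new, unique, unknown or untested is made for them only; others in the source may bear on it.

Compound 1 `COc1ccc2c(/C=C/C(=O)c3cc(OC)c(OC)c(SC)c3)c[nH]c2c1`: 101 nM
Compound 2 `COc1ccc2c(/C=C/C(=O)c3cc(OC)c(OC)c([N+](=O)[O-])c3)c[nH]c2c1`: 662 nM

In a functional assay on MCF7 cells (Homo sapiens) for antiproliferative activity, read by MTT assay, with a stated time of 48 h (a lower number here means a stronger inhibitor, a higher number a weaker inhibitor), compound 2 gives 662 nM, the higher of the two numbers and so the weaker inhibitor of the pair. Compound 3 `COc1ccc2c(/C=C/C(=O)c3cc(OC)c(OC)c([Se]C)c3)c[nH]c2c1` has not yet been measured. It differs from compound 2 by one change: a group of 2 heavy atoms (1 carbon, 1 selenium; no ring) in place of a group of 3 heavy atoms (1 nitrogen, 2 oxygen; no ring), on an aromatic carbon. The entering group sits on the aromatic carbon where compound 1 carries methylsulfanyl, with selenium in the place of sulfur. Among the compounds with values here, one measured step bears on this change: nitro in place of methylsulfanyl gave a 6.6-fold higher number from compound 1 to compound 2 (0.82 log units; beyond the scatter). The step to compound 3 runs the opposite way, so most of that difference is expected to be recovered, towards the value of compound 1 at 101 nM. In this assay the expected step is a 5.5-fold lower number from compound 2 to compound 3 (0.74 log units; beyond the scatter). Compound 3 is estimated at 120 nM, with an expected range of 45 nM to 320 nM.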

Compound 3, half-maximal inhibitory concentration: 83 nM
Estimate against measurement, compound 3: 1.4-fold (0.16 log units) above, and the stated range covers the measured number.
By their numbers in this assay, from the lowest: compounds 3 and 1 (each within the scatter of the next); then compound 2.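

In this assay, the selenium-bearing group in place of nitro gave an 8.0-fold lower number from compound 2 to compound 3 (0.90 log units; beyond the scatter), so a second group, and not methylsulfanyl alone, stands clearly apart from nitro on this aromatic carbon. Exchanging sulfur for selenium in that group gave a 1.2-fold lower number from compound 1 to compound 3 (0.09 log units; within the scatter), so the two groups cannot be told apart in this assay, and the atom can change here with no readable change in the number. Nothing measured here bears on why nitro differs from these two groups.

On these data alone, how an amine, a hydroxyl group or a longer chain such as ethylsulfanyl would read on this aromatic carbon remains open. As far as these compounds go, it is also open whether the match between the sulfur and selenium groups would hold in other cell lines or at other exposure times.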